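A few compounds are considered here, and "the series" means these few. Any claim that something is new, unique, unknown or untested is made for them only; others in the source may bear on it.

In an assay on microsomes from brain for inhibition of Fatty-acid amide hydrolase 1 (Rattus norvegicus), read by fluorescence and HPLC, with a stated time of 45 min (on this read-out higher numbers stand for weaker inhibition and lower numbers for stronger inhibition), compound 3 `COC(=O)Nc1ccc2c(cnn2CC(=O)COc2ccc(Oc3ccccc3)cc2)c1` gives 4000 nM. Its nearest neighbour among the measured compounds is compound 2 `N#CNC(COc1ccc(Oc2ccccc2)cc1)Cn1ncnn1`, which gives 5300 nM; the two numbers sit within the usual scatter of each other, so they cannot be told apart. Compound 1 `O=C(COc1ccc(Oc2ccccc2)cc1)Cn1ncnn1` gives 8 nM, a gap from compound 3 that lies far beyond the scatter, and compound 1 is the strongest inhibitor of the three.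

Compound 4 `CS(=O)(=O)NC(=O)c1ccc2c(cnn2CC(=O)COc2ccc(Oc3ccccc3)cc2)c1` has not yet been measured. It differs from compound 3 in a single place: (methylsulfonyl)carbamoyl in place of (methoxycarbonyl)amino on an aromatic carbon. For the measured compounds named here, no measured pair in this set shows a change of this kind, so there is no earlier step to lean on, and the two groups are judged only by what is counted above. The expectation is a step from compound 3 to compound 4 of a 1.3-fold higher number from compound 3 to compound 4 (0.10 log units; within the scatter), which is no more than the scatter allows in either direction. Compound 4 is therefore estimated to give 5000 nM in this assay, with a likely range from 1500 nM to 20000 nM.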

Compound 4, half-maximal inhibitory concentration: 770 nM
For compound 4 the middle estimate is 6.5-fold (0.81 log units) above the measured one; measured number below the stated range.
By their numbers in this assay, from the lowest: compound 1; then compound 4; then compounds 3 and 2 (each within the scatter of the next).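

In this assay, putting (methylsulfonyl)carbamoyl in place of (methoxycarbonyl)amino gives a 5.2-fold lower number from compound 3 to compound 4 (0.72 log units; beyond the scatter), so the group on this aromatic carbon can shift the read-out beyond the usual scatter. The earlier compounds shown here could not show this, as none of them formed a one-place pair. Two things change together in this step: the entering group brings a sulfur, and the atom joined to the ring changes from nitrogen to carbon, while nothing given here explains the stronger inhibition.

The compounds shown do not separate these two changes, and a carboxylic acid or a plain carboxamide on the same carbon would help to do so. On these data alone, it also remains open how an amine or a longer chain at this position would read.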